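Lengthening a Sulfur-Linked Chain in Search of Stronger Inhibition

The compounds below may be only part of what the source reports. "The series", "measured", "known", "first", "only" and "open" are said of these compounds alone.

Of the compounds shown here, three sharing one core have been tested in a functional assay on HGC-27 cells (Homo sapiens) for inhibition, read by MTT assay, with a stated time of 72 h; on this read-out higher numbers stand for weaker inhibition and lower numbers for stronger inhibition. Compound 1 `Cc1cc(N2CC[C@@H](C)[C@@H](N(C)c3ncnc4[nH]ccc34)C2)n2ncnc2n1` carries only hydrogen at the position of interest and gives 11300 nM. Compound 2 `Cc1cc(N2CC[C@@H](C)[C@@H](N(C)c3ncnc4[nH]ccc34)C2)n2nc(SCC3CC3)nc2n1` gives 21400 nM, and compound 3 `C=CCSc1nc2nc(C)cc(N3CC[C@@H](C)[C@@H](N(C)c4ncnc5[nH]ccc45)C3)n2n1` gives 35200 nM. Compound 3 thus has the highest number of the three, though its gap to compound 2 lies within the scatter; only its gap to compound 1, a 3.1-fold higher number from compound 1 to compound 3 (0.49 log units; beyond the scatter), lies beyond it.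

Compound 4 `Cc1cc(N2CC[C@@H](C)[C@@H](N(C)c3ncnc4[nH]ccc34)C2)n2nc(SCCCc3ccccc3)nc2n1` differs from compound 3 in one place: phenethyl in place of vinyl on a saturated chain carbon bound to a sulfur. The measured steps that bear on this are a 1.6-fold higher number from compound 2 to compound 3 (0.22 log units; within the scatter), which exchanges one small group for another on the same chain carbon, and a 1.9-fold higher number from compound 1 to compound 2 (0.28 log units; within the scatter) together with a 3.1-fold higher number from compound 1 to compound 3 (0.49 log units; beyond the scatter), which show what attaching these sulfur-linked chains to the core did. On these data alone, none of them involves an aromatic ring on the chain, so the effect of the phenethyl group itself is untested. Since adding chain to the core so far has not lowered the number, a small step upward or none beyond the scatter is expected in this assay. Compound 4 is therefore estimated at 40000 nM, within 15000 nM to 110000 nM, an expected step of a 1.1-fold higher number from compound 3 to compound 4 (0.06 log units; within the scatter).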

Compound 4, half-maximal inhibitory concentration: > 100000 nM
Compound 4 gave a limit, no number (the forecaster's own chance of this, stated with the estimate: 15%); at least 2.5-fold (0.39 log units) between middle value and limit.
By their numbers in this assay, from the lowest: compounds 1, 2 and 3 (each within the scatter of the next, the first and the last beyond it). At a limit, above all of these: compound 4.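

In this assay, the reading for compound 4 is a limit and not a number: the limit of > 100000 nM in this assay, at which 1 of the 4 values shown sits. Even read against that limit, phenethyl in place of vinyl gives an at least 2.8-fold higher number from compound 3 to compound 4 (0.45 log units; beyond the scatter), phenethyl in place of cyclopropyl gives an at least 4.6-fold higher number from compound 2 to compound 4 (0.66 log units; beyond the scatter), and (3-phenylpropyl)sulfanyl in place of hydrogen on the aromatic carbon gives an at least 8.8-fold higher number from compound 1 to compound 4 (0.94 log units; beyond the scatter). The two small groups on the saturated chain carbon bound to a sulfur, in compound 2 and compound 3, stayed within the scatter of each other, so this is the first change at that carbon shown here to move the number beyond the scatter, and it moves it toward weaker inhibition.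

On these data alone, how far past the limit compound 4 truly lies stays unknown, and the entering phenethyl group brings an aromatic ring and extra chain length together, so the two cannot be told apart. As far as these compounds go, what a plain pentyl chain on the sulfur would do remains open, as does the effect of a chain ending in an amine or a carboxylic acid.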